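Swapping 2-ethylphenyl for 2,6-dimethylphenyl in the series

The compounds below may be only part of what the source reports. "The series", "measured", "known", "first", "only" and "open" are said of these compounds alone.

Half-life values in an ADME assay on microsomes from liver (Rattus norvegicus) for metabolic stability, read by LC-MS, using NADPH, at 37 degrees C; on this read-out lower numbers stand for a shorter-lived compound and higher numbers for a longer-lived compound
- compound 1 `Cc1oc(-c2ccc(Cl)cc2)nc1CN1CCC(C(=O)NCCCN2C[C@H](C)C[C@H](C)C2)CC1` gives > 0.5 h (a limit of the assay, not a number)
- compound 2 `Cc1oc(-c2c(Cl)cccc2Cl)nc1CN1CCC(C(=O)NCCCN2C[C@H](C)C[C@H](C)C2)CC1` gives 0.0483 h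
- compound 3 `CCc1ccccc1-c1nc(CN2CCC(C(=O)NCCCN3C[C@H](C)C[C@H](C)C3)CC2)c(C)o1` gives 0.283 h

Compound 1 is known only as a limit. Of the two actual numbers, that of compound 3 is the higher (a 5.9-fold higher number from compound 2 to compound 3 (0.77 log units; beyond the scatter)).

Next comes compound 4 (`Cc1cccc(C)c1-c1nc(CN2CCC(C(=O)NCCCN3C[C@H](C)C[C@H](C)C3)CC2)c(C)o1`), with 2,6-dimethylphenyl in place of 2-ethylphenyl on an aromatic carbon. Three measured steps changed the same place. The large one is (an at least 10-fold lower number from compound 1 to compound 2 (1.01 log units; beyond the scatter)), the second is only a floor (an at least 1.7-fold lower number from compound 1 to compound 3 (0.24 log units; that floor lies within the scatter)), and the third is the modest step already given. The entering 2,6-dimethylphenyl has the same substitution pattern as the 2,6-dichlorophenyl of compound 2 (0.0483 h), and it is carbon-only like the 2-ethylphenyl of compound 3 (0.283 h). A position between these two values is therefore expected, closer to the upper one. A small downward step in this assay is expected (a 1.9-fold lower number from compound 3 to compound 4 (0.28 log units; within the scatter)). For compound 4 the estimated half-life is 0.15 h (range 0.05 h to 0.4 h).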

Compound 4, half-life: 0.0517 h
For compound 4 the middle estimate is 2.9-fold (0.46 log units) above the measured one; the range from low to high includes it.
By their numbers in this assay, from the lowest: compounds 2 and 4 (each within the scatter of the next); then compound 3. At a limit, above all of these: compound 1.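

With the same atoms joined differently, 2,6-dimethylphenyl in place of 2-ethylphenyl is not a neutral exchange in this assay: a 5.5-fold lower number from compound 3 to compound 4 (0.74 log units; beyond the scatter). In 2,6-dimethylphenyl in place of 2,6-dichlorophenyl, methyl and chlorine on the same pattern give no readable difference: a 1.1-fold higher number from compound 2 to compound 4 (0.03 log units; within the scatter). The step of an at least 9.6-fold lower number from compound 1 to compound 4 (0.98 log units; beyond the scatter) is only a floor, read from a limit: the limit of > 0.5 h in this assay, at which 1 of the 4 values shown sits.

Going by these compounds, whether 2-methylphenyl or 2,6-difluorophenyl at this position would sit with compound 3 or with compound 4 remains open. The half-lives also do not tell why the 2-ethylphenyl and 2,6-dimethylphenyl compounds differ, or which part of these molecules is consumed in the microsomes.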